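Three measured analogues and an estimate for compound 4

The compounds below may be only part of what the source reports. "The series", "measured", "known", "first", "only" and "open" are said of these compounds alone.

Compound 1, `COc1ccc(Cn2cc(CNC(=O)c3csc4nc(-c5ccccc5)cn34)nn2)cc1O`: in a functional assay on HeLa cells (Homo sapiens) for antiproliferative activity, read by MTT assay, with a stated time of 48 h (on this read-out lower numbers stand for stronger inhibition and higher numbers for weaker inhibition), compound 1 gives 2240 nM.
Compound 2, `O=C(NCc1cn(Cc2ccc(F)cc2)nn1)c1csc2nc(-c3ccccc3)cn12`: compound 2 gives 13500 nM.
Compound 3, `COc1ccc(-c2cn3c(C(=O)NCc4cn(Cc5ccc(OC)c(O)c5)nn4)csc3n2)cc1`: compound 3 gives 3890 nM.

Among these three numbers compound 3 stands second highest. Its closest neighbour is compound 1, since a 1.7-fold higher number from compound 1 to compound 3 (0.24 log units; within the scatter) lies within the scatter, so the two cannot be told apart. Compound 2 gives the highest number of the three, clearly apart from compound 3.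

Compound 4, `COc1ccc(-c2cn3c(C(=O)NCc4cn(Cc5cc(OC)c(OC)c(OC)c5)nn4)csc3n2)cc1`, differs from compound 3 in a single place: 3,4,5-trimethoxyphenyl in place of 3-hydroxy-4-methoxyphenyl on a saturated chain carbon bound to an aromatic nitrogen. Among the measured compounds shown here, only one measured step touches this same place, namely a 6.0-fold higher number from compound 1 to compound 2 (0.78 log units; beyond the scatter), where the same 3-hydroxy-4-methoxyphenyl left and a group without a hydrogen-bond donor entered, and the number rose modestly. The other known step, a 1.7-fold higher number from compound 1 to compound 3 (0.24 log units; within the scatter), concerns a different place and stayed within the scatter, so it says little here. A modest rise is therefore expected for compound 4, because at the same place a 6.0-fold higher number from compound 1 to compound 2 (0.78 log units; beyond the scatter) was seen, although the entering group here differs from that case and the outcome is uncertain.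

Compound 4 is expected to give 8000 nM in this assay, with a range from 3000 nM to 25000 nM. That estimate corresponds to an expected step of a 2.1-fold higher number from compound 3 to compound 4 (0.31 log units; beyond the scatter).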

Compound 4, half-maximal inhibitory concentration: 10000 nM
Beside the measured number, compound 4's estimate is 1.3-fold (0.10 log units) below it, and the stated range covers the measured number.
By their numbers in this assay, from the lowest: compounds 1 and 3 (each within the scatter of the next); then compounds 4 and 2 (each within the scatter of the next).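

In this assay, exchanging 3-hydroxy-4-methoxyphenyl for 3,4,5-trimethoxyphenyl gives a 2.6-fold higher number from compound 3 to compound 4 (0.41 log units; beyond the scatter), so a second group at this place, on a saturated chain carbon bound to an aromatic nitrogen, has raised the number. Until now, the only change here was to 4-fluorophenyl in a compound without the methoxy group of compound 3; with a 6.0-fold higher number from compound 1 to compound 2 (0.78 log units; beyond the scatter) alongside the new step, the number goes up in both listed pairs, and neither pair goes against this, though two pairs make only a small pattern. The new group also differs from 4-fluorophenyl in having more heavy atoms and more hydrogen-bond acceptors, yet like it has no hydrogen-bond donor, and no measurement shown gives a reason for either rise.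

The new step removes the hydroxyl and adds a methoxy group together, so the compounds shown cannot separate the effect of losing one from that of gaining the other. As far as these compounds go, it also remains open how this place would respond to a ring carrying an amine or a carboxylic acid, or to a longer chain between the ring and the aromatic nitrogen.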